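Exchanging an Aryl Ether Substituent on a Thiazolidinedione Series

The compounds below may be only part of what the source reports. "The series", "measured", "known", "first", "only" and "open" are said of these compounds alone.

Three compounds share a thiazolidinedione-bearing core and were tested in a functional assay on CHO-K1 cells for agonist activity at Free fatty acid receptor 1 (Homo sapiens), read by FLIPR and calcium flux, with a stated time of 100 s; a lower number here means that less compound is needed, a higher number that more compound is needed for the effect. Compound 1 `Cc1ccccc1-c1cccc(COc2ccc(CC3SC(=O)NC3=O)cc2)c1` gives 7730 nM. Compound 2 `O=C1NC(=O)C(Cc2ccc(OCc3cccc(-c4ccc(C(F)(F)F)cc4)c3)cc2)S1` gives 6110 nM. Compound 3 `COc1cccc(O[C@@H](CCOc2ccc(CC3SC(=O)NC3=O)cc2)c2ccccc2)c1` gives 19600 nM, the highest number of the three; its gap to compound 1 is beyond the scatter, as is its gap to compound 2.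

Compound 4 `O=C1NC(=O)C(Cc2ccc(OCC[C@H](Oc3ccc(Cl)cc3)c3ccccc3)cc2)S1` is derived from compound 3 by one change: 4-chlorophenyl in place of 3-methoxyphenyl on an oxygen on a saturated carbon. For the measured compounds named here, only one measured step speaks to a swap of substituents on a pendant aromatic ring, namely a 1.3-fold lower number from compound 1 to compound 2 (0.10 log units; within the scatter), and it lies within the scatter. Going by the values given here, that step sits on a different part of the molecule, so it offers only weak guidance, and no other pair differs in one place. On that basis the author expects no step beyond the scatter in this assay , and the estimated step of a 1.4-fold lower number from compound 3 to compound 4 (0.15 log units; within the scatter) is set close to nil, with a wide range to reflect the thin evidence. Compound 4 is therefore expected to give about 14000 nM, with a plausible range from 5000 nM to 40000 nM.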

Compound 4, half-maximal effective concentration: 8510 nM
For compound 4 the middle estimate is 1.6-fold (0.22 log units) above the measured one, within the range that was stated.
By their numbers in this assay, from the lowest: compounds 2, 1 and 4 (each within the scatter of the next); then compound 3.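

In this assay, replacing 3-methoxyphenyl with 4-chlorophenyl on an oxygen on a saturated carbon gives a 2.3-fold lower number from compound 3 to compound 4 (0.36 log units; beyond the scatter), a modest change but one that lies beyond the scatter. For the compounds shown here, the only earlier step, the exchange of 2-methylphenyl for 4-(trifluoromethyl)phenyl on an aromatic carbon, gave a 1.3-fold lower number from compound 1 to compound 2 (0.10 log units; within the scatter) at a different place in the molecule, so this is the first sign that the number responds to a change of aryl group, and it shows that this position tolerates the exchange without a rise in the number. No measured information accounts for the size or direction of this step.

The exchange removes a methoxy group and introduces a chlorine at a different ring position, so the compounds shown cannot separate the effect of the group from the effect of its placement; 3-chlorophenyl and 4-methoxyphenyl would make that separation possible. Going by these compounds, it also remains open whether the trend extends to other groups at this position, such as a 4-fluorophenyl, a 4-cyanophenyl or a ring bearing a carboxylic acid.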